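The source may hold more compounds than are shown below. What is called first, only, known or untested is meant among the compounds shown, and "the series" means these compounds.

Of the compounds shown here, two have been measured so far in an assay on isolated protein for inhibition of cathepsin S (Homo sapiens); on this read-out lower numbers stand for stronger inhibition and higher numbers for weaker inhibition. Compound 1 `COc1ccc(NCCNC(=O)[C@H](CC(C)C)NC(=O)c2cccc(OC)c2)cc1` gives 470 nM in this assay, while compound 2 `CC(C)C[C@H](NC(=O)OCc1ccccc1)C(=O)NCCNc1ccc(OC2CCCCC2)cc1` gives 1200 nM. Compound 2 therefore carries the higher of the two numbers, and its gap to compound 1 lies beyond the usual scatter of repeated measurements. Going by the values given here, the two compounds differ from each other in more than one place, so no step between compounds that differ in a single place is available, and nothing about the weight of any one change can be drawn from the pair.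

Compound 3 `CC(C)C[C@H](NC(=O)OCc1ccccc1)C(=O)NCCNc1ccc(OC2CCCC2)cc1` has not yet been measured. It is related to compound 2 by a single change, (cyclopentyl in place of cyclohexyl on an oxygen on an aromatic ring). Among the compounds with values here, no measured step of this kind exists here, so the expectation rests on the size of the change alone: a small shift in either direction, most likely none beyond the scatter. The step from compound 2 to compound 3 in this assay is expected to be no change at the digits printed from compound 2 to compound 3 (within the scatter). For compound 3 the estimate in this assay is 1200 nM, with a range from 500 nM to 3000 nM.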

Compound 3, half-maximal inhibitory concentration: 4400 nM
The estimate for compound 3 lay 3.7-fold (0.56 log units) below the measured number; measured number outside the range, above it.
By their numbers in this assay, from the lowest: compound 1; then compound 2; then compound 3.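

In this assay, the group on the oxygen on an aromatic ring proves to count at this position: cyclopentyl in place of cyclohexyl gives a 3.7-fold higher number from compound 2 to compound 3 (0.56 log units; beyond the scatter), so the loss of a single ring carbon is not a neutral exchange here. This is the first step shown that isolates one place in the series, and it places the cyclohexyl compound on the side of the lower number, although it remains a single pair on a single core and supports no wider trend. No supporting information is available that bears on the reason for this step.

The compounds shown leave open whether the number keeps falling as the ring grows, as it might with a cycloheptyl group, or whether a ring is needed at all, which an open chain such as n-hexyl or a ring carrying an amine, such as piperidinyl, would test at the same oxygen. They also leave open whether the exchange of cyclohexyloxy to cyclopentyloxy would have a step of similar size on a different core, such as that of compound 1.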